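This account rests on a few compounds, and the source may have more. Where it says the series, first, only, none or still open, it means among the compounds named here.

Of the compounds shown here, two sharing one core have been measured in a functional assay on Ehrlich cells (Mus musculus) for antiproliferative activity, read by trypan blue exclusion, with a stated time of 2 h, tested at 10 ug/mL; a lower number here means a weaker effect, a higher number a stronger effect of the compound at the concentration tested. Compound 1 `N#CC1=C(N)N(c2ccc(S(N)(=O)=O)cc2)C2=C(C(=O)CCC2)C1c1cccc([N+](=O)[O-])c1` carries a 3-nitrophenyl on a saturated ring carbon, and in this assay compound 1 gives 42%. Compound 2 `N#CC1=C(N)N(c2ccc(S(N)(=O)=O)cc2)C2=C(C(=O)CCC2)C1c1c(O)ccc2ccccc12` carries a 2-hydroxynaphthalen-1-yl in that same place, and in this assay compound 2 gives 0%. For the measured compounds named here, compound 2 therefore stands at the lower of the two numbers, at the very floor of the read-out, the only measured step being a number 42 percentage points lower from compound 1 to compound 2 (beyond the scatter).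

Compound 3 `COc1ccc2ccccc2c1C1C(C#N)=C(N)N(c2ccc(S(N)(=O)=O)cc2)C2=C1C(=O)CCC2` has not yet been measured. It differs from compound 2 by methyl in place of hydrogen on an oxygen on an aromatic ring, so hydroxy becomes methoxy and 2-hydroxynaphthalen-1-yl becomes 2-methoxynaphthalen-1-yl. Going by the values given here, no measured step touches this oxygen: the one known step, a number 42 percentage points lower from compound 1 to compound 2 (beyond the scatter), exchanges the whole aromatic group and tells nothing about a methyl on oxygen. Since compound 2 already sits at the bottom of the scale, the expected step is a number 5 percentage points higher from compound 2 to compound 3 (within the scatter), which would stay within the usual scatter. Compound 3 is estimated at 5%, in a range from 0% to 20%.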

Compound 3, a percentage reported as activity, at one concentration (the size of the read-out at that concentration, not a potency): 40%
Compound 3: the middle estimate sits 35 percentage points below what was measured, outside the stated range (above it).
By their numbers in this assay, from the lowest: compound 2; then compounds 3 and 1 (each within the scatter of the next).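

Adding one methyl to the oxygen on the aromatic ring changes the result in this assay by a large margin, with a number 40 percentage points higher from compound 2 to compound 3 (beyond the scatter). The 2-methoxynaphthalen-1-yl group of compound 3 differs from the 2-hydroxynaphthalen-1-yl group of compound 2 only by this methyl in place of hydrogen. A low read-out is therefore not shared by both groups at this saturated ring carbon. Exchanging the aromatic group now gives a much smaller difference, with a number 2 percentage points lower from compound 1 to compound 3 (within the scatter), which lies within the scatter, so 2-methoxynaphthalen-1-yl and 3-nitrophenyl cannot be told apart here, and the data available give no explanation for why this one small change on oxygen matters so much.

The compounds shown leave open whether a longer chain on this oxygen, such as ethyl or propyl, would keep the read-out of compound 3, and whether an amine in place of the hydroxy would resemble compound 2 or compound 3. Each result also comes from one concentration, so the similar read-outs of compound 1 and compound 3 describe the size of the effect at that concentration only and do not show that the two would match at other concentrations.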